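A few compounds are considered here, and "the series" means these few. Any claim that something is new, unique, unknown or untested is made for them only; others in the source may bear on it.

Measured so far in a functional assay on H184B5F5/M10 cells (Homo sapiens) for antiproliferative activity, read by XTT assay, with a stated time of 72 h; on this read-out higher numbers stand for weaker inhibition and lower numbers for stronger inhibition:
Compound 1, `COc1ccc(-c2cc3ccccc3nc2/C=C/C(=O)c2ccccn2)cc1`, gives 4140 nM.
Compound 2, `COc1ccc(-c2cc3ccccc3nc2/C=C/C(=O)c2ccc(Br)s2)cc1`, gives 9380 nM.
Compound 3, `COc1ccc(-c2cc3ccccc3nc2/C=C/C(=O)c2sccc2N)cc1`, reaches only the assay limit of > 10000 nM and so has no exact number (the limit of > 10000 nM in this assay, at which 1 of the 3 values shown sits).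

Compound 3 therefore stands at the limit, reached through an at least 2.4-fold higher number from compound 1 to compound 3 (0.38 log units; beyond the scatter) and an at least 1.0-fold higher number from compound 2 to compound 3 (0.02 log units; that floor lies within the scatter). Compound 4, `COc1ccc(-c2cc3ccccc3nc2/C=C/C(=O)c2cnc(N)nc2C)cc1`, differs from compound 3 by 2-amino-4-methylpyrimidin-5-yl in place of 3-aminothiophen-2-yl on a carbonyl carbon. The measured steps that bear on this change the ring on the carbonyl carbon: a 2.3-fold higher number from compound 1 to compound 2 (0.36 log units; beyond the scatter) and an at least 2.4-fold higher number from compound 1 to compound 3 (0.38 log units; beyond the scatter), both modest, and compound 1 with pyridin-2-yl on that carbon gives the lowest number shown. A modest move toward a lower number in this assay is expected for compound 4, namely an at least 1.6-fold lower number from compound 3 to compound 4 (0.22 log units; that floor lies within the scatter). Compound 4 is estimated at 6000 nM, within 2000 nM to 15000 nM.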

Compound 4, half-maximal inhibitory concentration: > 10000 nM
Compound 4 ended at the assay's limit; the forecaster's own chance of this, stated with the estimate: 35%; middle value at least 1.6-fold (0.22 log units) away from the limit.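

In this assay compound 4 gives > 10000 nM, which is a limit of the assay and not a number, so the step involving compound 3 cannot be read. With 2-amino-4-methylpyrimidin-5-yl on the carbonyl carbon there is an at least 2.4-fold higher number from compound 1 to compound 4 (0.38 log units; beyond the scatter), so a six-membered aromatic ring there is not enough to keep the lower number. Against 5-bromothiophen-2-yl there is an at least 1.0-fold higher number from compound 2 to compound 4 (0.02 log units; that floor lies within the scatter), so no order can be claimed for that pair.

Going by these compounds, whether a plain phenyl ring on this carbonyl carbon would give a lower number than compound 1 stays open. So does how far past the limit compound 3 and compound 4 lie.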